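Nitro for chloro on the pendant ring

The source may report more compounds than this note shows. Statements on the series, on what has been measured and on what is new or still open speak of the compounds shown alone.

Compound 3 `Nc1scc(-c2cccc(Cl)c2)c1C(=O)c1ccc(Cl)cc1` stands at the top of the three numbers in a functional assay on CHO cells for agonist activity at adenosine receptor A1 (Homo sapiens), read by fluorescence and ERK phosphorylation, with stated times of 30 min and 1.5 h, tested at 3 uM (a higher number here means a stronger effect of the compound at the concentration tested, a lower number a weaker effect), where compound 3 gives 58%. Its nearest neighbour is compound 2 `Nc1scc(-c2ccccc2)c1C(=O)c1ccc(Cl)cc1`, which in this assay gives 51%; the step of a number 7 percentage points higher from compound 2 to compound 3 (within the scatter) lies within the scatter, so compound 3 cannot be called stronger than compound 2. Only the gap to compound 1 `Nc1scc(-c2cccc([N+](=O)[O-])c2)c1C(=O)c1ccccc1`, which in this assay gives 47%, lies beyond the scatter.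

Compound 4 `Nc1scc(-c2cccc([N+](=O)[O-])c2)c1C(=O)c1ccc(Cl)cc1` is compound 3 with nitro in place of chloro on an aromatic carbon. For the measured compounds named here, the only measured single step, hydrogen to chloro at the same kind of site, a number 7 percentage points higher from compound 2 to compound 3 (within the scatter), is small and within the scatter. No measured step swaps chloro for nitro; compound 1 carries the nitro but a different acyl ring and is the lowest number shown, while compound 2 and compound 3 share the acyl ring of compound 4. Taken together, a step downward is expected but of a size that may not clear the scatter, with a number 8 percentage points lower from compound 3 to compound 4 (within the scatter) as the estimated step from compound 3 to compound 4.

For compound 4 the expected value in this assay is 50%, within a range from 38% to 62%.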

Compound 4, a percentage reported as activity, at one concentration (the size of the read-out at that concentration, not a potency): 53%
Estimate against measurement, compound 4: 3 percentage points below; low and high end bracket the measured number.
By their numbers in this assay, from the lowest: compounds 1, 2, 4 and 3 (each within the scatter of the next, the first and the last beyond it).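

Swapping chloro for nitro on an aromatic carbon of the pendant ring, meta to a large group, gives no step that can be told from the scatter in this assay: a number 5 percentage points lower from compound 3 to compound 4 (within the scatter). Nitro in place of hydrogen at the same place reads the same way, a number 2 percentage points higher from compound 2 to compound 4 (within the scatter), so hydrogen, chloro and nitro at this position all lie within the scatter of one another on the core shared by compound 2, compound 3 and compound 4, despite the larger group and its added hydrogen-bond acceptors. Chloro in place of hydrogen on the acyl ring, with nitro held on the pendant ring, gives a number 6 percentage points higher from compound 1 to compound 4 (within the scatter), and this step agrees with the one seen for chloro on the pendant ring: the same change on two cores in this assay, a number 7 percentage points higher (within the scatter) from compound 2 to compound 3 and a number 6 percentage points higher (within the scatter) from compound 1 to compound 4, 1 percentage points apart, within the scatter of two such steps.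

From the compounds shown here alone, whether any group at this position can move the read-out beyond the scatter stays open, for instance an amine, a carboxylic acid or a longer chain such as a butyl group. All these numbers give the size of the effect at one concentration, so they say nothing about how the potencies of these compounds compare.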